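Swapping a pyridine for a thiophene on the shared core

The source may report more compounds than this note shows. Statements on the series, on what has been measured and on what is new or still open speak of the compounds shown alone.

Compound 1 `Oc1ccc(-c2cc(-c3ccc(Cl)cc3)nc(-c3cccnc3)c2)cc1` gives the highest number among three compounds tested in a functional assay on HCT-15 cells (Homo sapiens) for cytotoxicity, read by CCK-8 assay and cell counting, with a stated time of 2 days (a higher number here means a weaker inhibitor, a lower number a stronger inhibitor), where compound 1 gives 20700 nM. Compound 3 `Oc1cccc(-c2cc(-c3ccc(Cl)cc3)nc(-c3cccnc3)c2)c1` gives 16800 nM, and the step of a 1.2-fold lower number from compound 1 to compound 3 (0.09 log units; within the scatter) shows how little that change matters. Compound 2 `Oc1ccc(-c2cc(-c3ccco3)nc(-c3ccccc3Cl)c2)cc1` gives 5460 nM; it differs from compound 1 in more than one place, so the two values can only be set side by side.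

Compound 4 `Oc1ccc(-c2cc(-c3ccc(Cl)cc3)nc(-c3ccsc3)c2)cc1` is compound 1 with thiophen-3-yl in place of pyridin-3-yl on an aromatic carbon. Among the compounds with values here, no measured step touches this group: the only single-point step, a 1.2-fold lower number from compound 1 to compound 3 (0.09 log units; within the scatter), concerns the hydroxyphenyl group and stays within the scatter. With nothing pointing either way, no step beyond the scatter is expected here, which means an expected step of a 1.3-fold lower number from compound 1 to compound 4 (0.11 log units; within the scatter). Compound 4 is therefore expected to give about 16000 nM, with a range from 5000 nM to 50000 nM.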

Compound 4, half-maximal inhibitory concentration: 6240 nM
Beside the measured number, compound 4's estimate is 2.6-fold (0.41 log units) above it; the range from low to high includes it.
By their numbers in this assay, from the lowest: compounds 2 and 4 (each within the scatter of the next); then compounds 3 and 1 (each within the scatter of the next).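

Among the compounds shown, this position is the first where a single change moves the number beyond the scatter: in this assay, thiophen-3-yl in place of pyridin-3-yl gives a 3.3-fold lower number from compound 1 to compound 4 (0.52 log units; beyond the scatter), whereas moving the hydroxyl group on the hydroxyphenyl ring gave only a 1.2-fold lower number from compound 1 to compound 3 (0.09 log units; within the scatter). The swap replaces a six-membered aromatic ring with a five-membered one and nitrogen with sulfur as the hetero atom, while the counts of hydrogen-bond donors and acceptors stay the same. Nothing available explains why this swap lowers the number.

The compounds shown cannot separate the effect of ring size from that of the hetero atom. As far as these compounds go, how a plain phenyl ring or a pyridine carrying an amine would behave at this position also remains open.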